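Replacing methyl with phenyl on the piperazine nitrogen

The compounds below may be only part of what the source reports. "The series", "measured", "known", "first", "only" and "open" are said of these compounds alone.

Measured compounds:
compound 1, `c1ccc(CN2CCN(CCCc3c[nH]c4ccc(-n5cnnc5)cc34)CC2)nc1`, 0.4 nM
compound 2, `c1c[nH]c(CN2CCN(CCCc3c[nH]c4ccc(-n5cnnc5)cc34)CC2)n1`, 1.6 nM
compound 3, `CN1CCN(CCCc2c[nH]c3ccc(-n4cnnc4)cc23)CC1`, 33 nM

All three compounds were tested in an assay on CHO cells for displacement of a labelled ligand from 5-hydroxytryptamine receptor 1D (Homo sapiens); a higher number here means a weaker inhibitor, a lower number a stronger inhibitor. Compound 3 stands highest of the three, that is, it is the weakest inhibitor of the set: compound 2 lies nearest to it, and compound 1 lies furthest away, as the steps of a 21-fold higher number from compound 2 to compound 3 (1.31 log units; beyond the scatter) and an 83-fold higher number from compound 1 to compound 3 (1.92 log units; beyond the scatter) show. Both of those steps are large and beyond the scatter, and both describe the same kind of change: the loss of an aromatic ring from the saturated chain carbon bound to the ring nitrogen, leaving only a hydrogen there. The step of a 4.0-fold higher number from compound 1 to compound 2 (0.60 log units; beyond the scatter) shows that the two aromatic rings themselves differ only modestly.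

Compound 4, `c1ccc(N2CCN(CCCc3c[nH]c4ccc(-n5cnnc5)cc34)CC2)cc1`, has not yet been measured. The change from compound 3 is phenyl in place of methyl on an amine nitrogen in a ring. Here the aromatic ring sits directly on the ring nitrogen rather than on a chain carbon, so the measured steps match it only in kind, not in place. Still, in both steps an aromatic ring at this end of the molecule went with a much lower number, so a lower number for compound 4 is expected, with a step of roughly a 6.6-fold lower number from compound 3 to compound 4 (0.82 log units; beyond the scatter). The estimate for compound 4 is 5 nM, within the range 1 nM to 25 nM.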

Compound 4, half-maximal inhibitory concentration: 1.4 nM
Compound 4: the middle estimate sits 3.6-fold (0.55 log units) above what was measured; measured number inside the range.
By their numbers in this assay, from the lowest: compound 1; then compounds 4 and 2 (each within the scatter of the next); then compound 3.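

In this assay, among these compounds, the earlier compounds showed aromatic rings only on a saturated chain carbon, but phenyl in place of methyl on an amine nitrogen in a ring gives a 24-fold lower number from compound 3 to compound 4 (1.37 log units; beyond the scatter), so an aromatic ring at this end also goes with a much lower number without that chain carbon. The comparison with the imidazole compound gives a 1.1-fold lower number from compound 2 to compound 4 (0.06 log units; within the scatter), which shows that a ring of carbon only, with no hydrogen-bond donors or acceptors, can match (1H-imidazol-2-yl)methyl here. The comparison with the pyridine compound gives a 3.5-fold higher number from compound 1 to compound 4 (0.54 log units; beyond the scatter), a modest gap, but this change alters both the ring and the presence of the chain carbon, so neither can be held responsible for it alone.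

Benzyl on this nitrogen, or pyridin-2-yl placed on it with no chain carbon, would separate those two changes, and the compounds shown include neither group. Nothing measured here explains why an aromatic ring at this position goes with a lower number in this assay.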